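Two Binders and a Benzyl Ester Analogue

A few compounds are considered here, and "the series" means these few. Any claim that something is new, unique, unknown or untested is made for them only; others in the source may bear on it.

Measured compounds:
compound 1, `CC1=C(C(=O)OCc2ccccc2)C(c2ccco2)NC(=S)N1`, 4%
compound 2, `COC(=O)C1=C(C)NC(=S)NC1c1ccsc1`, 3%

In an assay on membranes from HeLa cells for displacement of a labelled ligand from adenosine receptor A3 (Homo sapiens), read by scintillation counting, with a stated time of 180 min, tested at 1 uM (a higher number here means more inhibition at the concentration tested (going by the name of the read-out), a lower number less inhibition), compound 1 gives 4%, and compound 2 gives 3%. Compound 2 thus sits alongside compound 1, the two numbers within the scatter of each other and both near the floor of this assay. Compound 3, `CC1=C(C(=O)OCc2ccccc2)C(c2ccsc2)NC(=S)N1`, has not been measured; it differs from compound 2 by phenyl in place of hydrogen on a saturated chain carbon bound to an oxygen next to a carbonyl group. No step beyond the scatter is expected in this assay, because compound 1, which carries the same benzyl ester, gives 4%. Compound 3 is therefore expected to give 4%, between 0% and 12%. The expected step is a number 1 percentage points higher from compound 2 to compound 3 (within the scatter).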

Compound 3, a percentage reported as inhibition, at one concentration (the size of the read-out at that concentration, not a potency): 2%
Beside the measured number, compound 3's estimate is 2 percentage points above it; low and high end bracket the measured number.
By their numbers in this assay, from the lowest: compounds 3, 2 and 1 (each within the scatter of the next).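

Phenyl in place of hydrogen on the saturated chain carbon bound to an oxygen next to a carbonyl group gives a number 1 percentage points lower from compound 2 to compound 3 (within the scatter) in this assay and so, with thiophen-3-yl held constant, leaves the read-out unmoved beyond the scatter. With the benzyl ester held constant, thiophen-3-yl in place of furan-2-yl on the saturated ring carbon gives a number 2 percentage points lower from compound 1 to compound 3 (within the scatter) and likewise stays within the scatter. From the compounds shown here alone, whether a carboxylic acid or an amine at the ester position would lift the read-out remains open. No evidence on hand bears on these readings.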